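Adding a second chloro group to compound 3

The compounds below may be only part of what the source reports. "The series", "measured", "known", "first", "only" and "open" are said of these compounds alone.

In a functional assay on MCF7 cells (Homo sapiens) for antiproliferative activity, read by MTT assay, with a stated time of 48 h (a lower number here means a stronger inhibitor, a higher number a weaker inhibitor), compound 1 (`O=[N+]([O-])c1cc(C(F)(F)F)cc([N+](=O)[O-])c1Oc1ccccc1/C=N\OCc1ccccc1`) gives 1330 nM and compound 2 (`O=[N+]([O-])c1cc(C(F)(F)F)cc([N+](=O)[O-])c1Oc1ccccc1/C=N\OCc1ccccc1F`) gives 700 nM while compound 3 (`O=[N+]([O-])c1cc(C(F)(F)F)cc([N+](=O)[O-])c1Oc1ccccc1/C=N/OCc1ccccc1Cl`) gives 1100 nM as its reading. Compound 3 is separated from neither of the others by more than the scatter, as a 1.6-fold higher number from compound 2 to compound 3 (0.20 log units; within the scatter) and a 1.2-fold lower number from compound 1 to compound 3 (0.08 log units; within the scatter) show. Compound 4 (`O=[N+]([O-])c1cc(C(F)(F)F)cc([N+](=O)[O-])c1Oc1ccccc1/C=N/OCc1ccc(Cl)cc1Cl`) replaces the 2-chlorobenzyl group of compound 3 with a 2,4-dichlorobenzyl group (chloro in place of hydrogen on an aromatic carbon), which is chloro in place of hydrogen on an aromatic carbon, para to a large group. The nearest guides are the single halogen additions to the same ring of compound 1, seen in a 1.9-fold lower number from compound 1 to compound 2 (0.28 log units; within the scatter) and in the chloro step already given. Neither lies beyond the scatter, and neither concerns the carbon that changes here, so they guide only loosely. No step beyond the scatter is therefore expected in this assay and the expected step is a 1.2-fold lower number from compound 3 to compound 4 (0.09 log units; within the scatter) in size. Compound 4 is estimated at 900 nM within a range of 400 nM to 2000 nM for now.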

Compound 4, half-maximal inhibitory concentration: 940 nM
Compound 4: the middle estimate sits 1.0-fold (0.02 log units) below what was measured; measured number inside the range.
By their numbers in this assay, from the lowest: compounds 2, 4, 3 and 1 (each within the scatter of the next).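

In this assay the step is a 1.2-fold lower number from compound 3 to compound 4 (0.07 log units; within the scatter), so a chloro group on this aromatic carbon, para to a large group and meta to the chloro group already present, leaves the reading within the scatter of compound 3. Among the compounds shown here, the earlier steps concerned other carbons of this ring, so this is the first reading at this carbon, and it shows that going from 2-chlorobenzyl to 2,4-dichlorobenzyl brings no step beyond the scatter. No measurement at hand explains this result.

On these data alone, whether this carbon tolerates something other than a halogen, such as an amine, a carboxylic acid or a methoxy group, remains open. As far as these compounds go, it is also open whether the chloro group here would give the same reading without the chloro group it is meta to.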